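The source may report more compounds than this note shows. Statements on the series, on what has been measured and on what is new or still open speak of the compounds shown alone.

Measured compounds in a functional assay on DLD-1 cells (Homo sapiens); a higher number here means a weaker inhibitor, a lower number a stronger inhibitor:
compound 1 `N#Cc1ccc(Cn2cncc2CN(C(=O)c2ccccc2)c2ccc(N3CCN(C(=O)c4ccc(Cl)s4)CC3)cc2)cc1` gives 3 nM
compound 2 `N#Cc1ccc(Cn2cncc2CN(c2ccc(N3CCN(C(=O)c4ccc(Cl)s4)CC3)cc2)S(=O)(=O)c2ccccc2)cc1` gives 200 nM
compound 3 `N#Cc1ccc(Cn2cncc2CN(C(=O)c2cccc(Cl)c2)c2ccc(N3CCN(C(=O)c4ccc(Cl)s4)CC3)cc2)cc1` gives 2 nM

Compound 3 holds the lowest of the three numbers in this assay. Its nearest neighbour is compound 1, since a 1.5-fold lower number from compound 1 to compound 3 (0.18 log units; within the scatter); its furthest is compound 2, since a 100-fold lower number from compound 2 to compound 3 (2.00 log units; beyond the scatter). Compound 4 `N#Cc1ccc(Cn2cncc2CN(C(=O)c2ccccc2F)c2ccc(N3CCN(C(=O)c4ccc(Cl)s4)CC3)cc2)cc1` differs from compound 3 in one place: 2-fluorophenyl in place of 3-chlorophenyl on a carbonyl carbon.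

Among the measured compounds shown here, only one measured step touches the same ring while leaving the carbonyl in place, and that is a 1.5-fold lower number from compound 1 to compound 3 (0.18 log units; within the scatter). For the measured compounds named here, the other two steps, a 67-fold higher number from compound 1 to compound 2 (1.82 log units; beyond the scatter) and a 100-fold lower number from compound 2 to compound 3 (2.00 log units; beyond the scatter), swap the whole benzoyl group for a phenylsulfonyl group, a change of a different kind from the one between compound 3 and compound 4, so they do not speak directly to it.

Compound 4 is therefore expected to come out close to compound 3, with a step of a 1.5-fold higher number from compound 3 to compound 4 (0.18 log units; within the scatter), not beyond the scatter. The estimate for compound 4 in this assay is 3 nM, in a range from 1 nM to 10 nM.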

Compound 4, half-maximal inhibitory concentration: 20 nM
Beside the measured number, compound 4's estimate is 6.7-fold (0.82 log units) below it, and the stated range ends below it.
By their numbers in this assay, from the lowest: compounds 3 and 1 (each within the scatter of the next); then compound 4; then compound 2.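

In this assay, among the compounds shown here, the ring on this carbonyl carbon proves sensitive to what it carries: a 10-fold higher number from compound 3 to compound 4 (1.00 log units; beyond the scatter) is a step beyond the scatter, whereas the only earlier change on this ring, from compound 1 to compound 3, stayed within it. Fluoro in place of hydrogen also gives a 6.7-fold higher number from compound 1 to compound 4 (0.82 log units; beyond the scatter), so among these three compounds, the chloro compound stays level with the unsubstituted benzoyl compound while the fluoro compound does not. The carbonyl-linked ring still keeps a clear margin over the phenylsulfonyl group, with a 10-fold lower number from compound 2 to compound 4 (1.00 log units; beyond the scatter).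

Nothing available here accounts for these differences. From the compounds shown here alone, whether the change of halogen or its place on the ring produces the step remains open, as does the effect of an amine or a carboxylic acid on this ring.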